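Methoxy for Methyl in Two Weak Melanoma Cell Inhibitors

The compounds below may be only part of what the source reports. "The series", "measured", "known", "first", "only" and "open" are said of these compounds alone.

Compound 1 `Cc1ccc2c(c1)-c1cnc(n1C)OCCCCCCCCO2` and compound 2 `COc1ccc2c(c1)-c1cnc(n1C)OCCCCCCCCO2` share one core. In a functional assay on SK-MEL-28 cells (Homo sapiens) for inhibition, read by colorimetric assay and MTT assay, with a stated time of 72 h (a higher number here means a weaker inhibitor, a lower number a stronger inhibitor), compound 1 gives 55000 nM and compound 2 gives 57000 nM. For the measured compounds named here, the single change between them is methoxy in place of methyl on an aromatic carbon, and the step is a 1.0-fold higher number from compound 1 to compound 2 (0.02 log units; within the scatter). Compound 3 `C=CCCCCOc1ccc(C)cc1-c1cnc(OCCC=C)n1C` is built on a different core; the difference between the two cores is not broken down here. In this assay compound 3 gives 83000 nM. Compound 4 `C=CCCCCOc1ccc(OC)cc1-c1cnc(OCCC=C)n1C` has not yet been measured and differs from compound 3 by methoxy in place of methyl on an aromatic carbon. Going by the values given here, this is the same kind of change as the one from compound 1 to compound 2, but the surroundings differ: in compound 1 the carbon is part of a fused or bridged system of three rings, meta to a fused ring and para to a fused ring, while in compound 3 it is meta to a large group and para to a (hex-5-en-1-yl)oxy group. Since the earlier step of a 1.0-fold higher number from compound 1 to compound 2 (0.02 log units; within the scatter) lay within the scatter, the expected step here is a 1.0-fold higher number from compound 3 to compound 4 (0.02 log units; within the scatter) in this assay. Compound 4 is estimated at 86000 nM in this assay, with an expected range from 40000 nM to 180000 nM.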

Compound 4, half-maximal inhibitory concentration: 62000 nM
For compound 4 the middle estimate is 1.4-fold (0.14 log units) above the measured one; the range from low to high includes it.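

In this assay, putting methoxy in place of methyl on the core of compound 3 gives a 1.3-fold lower number from compound 3 to compound 4 (0.13 log units; within the scatter) and so leaves the number where it was, as far as this measurement can tell. Set beside the same change on the core of compound 1, the two steps agree: the same change on two cores in this assay, a 1.0-fold higher number (0.02 log units; within the scatter) from compound 1 to compound 2 and a 1.3-fold lower number (0.13 log units; within the scatter) from compound 3 to compound 4, 1.4-fold (0.14 log units) apart, within the scatter of two such steps. This shows that on these two cores the change has no readable effect in this assay, and that the absence of an effect carries from one core to the other; it does not show that the step would stay this small on any further core, and two pairs cannot reveal a real effect smaller than the scatter.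

The compounds shown leave open how other groups on this aromatic carbon, such as an amine or a carboxylic acid, would read in this assay. They also leave open what a longer chain in place of the (hex-5-en-1-yl)oxy group would do to the number.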